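Swapping the terminal amide-bearing ring on a shared core

The source may hold more compounds than are shown below. What is called first, only, known or untested is meant among the compounds shown, and "the series" means these compounds.

Three compounds from one series share a core and differ only in the basic side chain. Compound 1 `CC(=O)N1CCN(CCN2CCC(CNC(=O)c3cccc4[nH]c(C(C)C)nc34)CC2)CC1` gives 76% in a functional assay for agonist activity at 5-hydroxytryptamine receptor 4 (Homo sapiens), read by cAMP accumulation; on this read-out lower numbers stand for smaller maximal responses and higher numbers for larger maximal responses. Compound 2 `COC(=O)N1CCN(CCN2CCC(CNC(=O)c3cccc4[nH]c(C(C)C)nc34)CC2)CC1` gives 72% in this assay, and compound 3 `CS(=O)(=O)N1CCN(CC(O)CN2CCC(CNC(=O)c3cccc4[nH]c(C5CC5)nc34)CC2)CC1` gives 64%. Compound 2 stands close to both of the others: its nearest neighbour is compound 1 and its furthest is compound 3, and both gaps lie within the usual scatter of this read-out. For the measured compounds named here, the one single-point step among the measured compounds is a number 4 percentage points lower from compound 1 to compound 2 (within the scatter), which changes nothing beyond the noise.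

Compound 4 `CC(=O)N1CCC(CN2CCC(CNC(=O)c3cccc4[nH]c(C(C)C)nc34)CC2)CC1` is not yet measured. It differs from compound 2 by 1-acetylpiperidin-4-yl in place of (4-(methoxycarbonyl)piperazin-1-yl)methyl on a saturated chain carbon bound to an amine nitrogen in a ring. Going by the values given here, no measured step touches this part of the molecule, so the only guide is that the one measured change to the terminal group, a number 4 percentage points lower from compound 1 to compound 2 (within the scatter), left the number essentially unchanged. Compound 4 is therefore expected to give 72%, in a range from 58% to 86%, a step of no change at the digits printed from compound 2 to compound 4 (within the scatter) that is estimated to stay within the scatter.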

Compound 4, intrinsic activity: the largest response reached, in percent of the reference agonist's: 87%
The estimate for compound 4 lay 15 percentage points below the measured number; measured number outside the range, above it.
By their numbers in this assay, from the lowest: compounds 3, 2 and 1 (each within the scatter of the next, the first and the last beyond it); then compound 4.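

With the acetyl group held, 1-acetylpiperidin-4-yl in place of (4-acetylpiperazin-1-yl)methyl gives a number 11 percentage points higher from compound 1 to compound 4 (beyond the scatter) in this assay, and the same group in place of (4-(methoxycarbonyl)piperazin-1-yl)methyl gives a number 15 percentage points higher from compound 2 to compound 4 (beyond the scatter). Both steps lie beyond the scatter, unlike a number 4 percentage points lower from compound 1 to compound 2 (within the scatter), so among these compounds the ring and its link to the chain carbon bear on the maximal response more than the choice between the two terminal carbonyl groups does. Nothing available explains the rise.

The two steps exchange the ring and the link together, so the compounds shown do not separate their contributions. Also open, on these data alone, is whether the higher response persists with a propanoyl group, a carboxylic acid or a free amine in place of the acetyl on the piperidine ring.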